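Varying the aryl group on a dihydropyran core

This account rests on a few compounds, and the source may have more. Where it says the series, first, only, none or still open, it means among the compounds named here.

Compound 1 `N#CC1=C(N)OC(c2c[nH]c3ccccc23)=C(C#N)C1c1ccccc1F`: "not active" (no number reported)
Compound 2 `N#CC1=C(N)OC(c2c[nH]c3ccccc23)=C(C#N)C1c1ccc(Br)cc1`: 10.6%
Compound 3 `COc1ccc(C2C(C#N)=C(N)OC(c3c[nH]c4ccccc34)=C2C#N)cc1OC`: 26.1%

In a functional assay, tested at 200 ug/mL (a lower number here means a weaker effect, a higher number a stronger effect of the compound at the concentration tested), compound 1 is reported without a number, as not active. Compound 2 gives 10.6% in this assay, and compound 3 gives 26.1%, which is the highest of the two numbers available. Within the data shown here, the step of a number 15.5 percentage points higher from compound 2 to compound 3 (beyond the scatter) is the only measured step, and it lies beyond the scatter.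

Compound 4 `Cc1ccccc1C1C(C#N)=C(N)OC(c2c[nH]c3ccccc23)=C1C#N` has not been measured in this assay. It differs from compound 3 by 2-methylphenyl in place of 3,4-dimethoxyphenyl on a saturated ring carbon. Among the measured compounds shown here, the one measured step bears on this change in reverse: the 3,4-dimethoxyphenyl that is now removed was the group whose entry gave a number 15.5 percentage points higher from compound 2 to compound 3 (beyond the scatter), a modest rise. Removing it in favour of 2-methylphenyl is therefore expected to bring a step of about a number 17.1 percentage points lower from compound 3 to compound 4 (beyond the scatter) in this assay, back toward the level of compound 2, with the possibility that, as for compound 1, no number is reported at all. Compound 4 is accordingly estimated to give 9% in this assay, within a range of 0% to 22%.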

Compound 4, a percentage reported as activity, at one concentration (the size of the read-out at that concentration, not a potency): 21.4%
Estimate against measurement, compound 4: 12.4 percentage points below; low and high end bracket the measured number.
By their numbers in this assay, from the lowest: compound 2; then compounds 4 and 3 (each within the scatter of the next).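

In this assay, the 2-methylphenyl group, which has no oxygen and no hydrogen-bond acceptors, cannot be told apart from the 3,4-dimethoxyphenyl group on the saturated ring carbon, with a number 4.7 percentage points lower from compound 3 to compound 4 (within the scatter), so the two methoxy groups are not needed at this position for a read-out of this size. Set against the 4-bromophenyl group at the same position, the 2-methylphenyl group gives a number 10.8 percentage points higher from compound 2 to compound 4 (beyond the scatter), which leaves compound 2 with the lowest number of the three and shows that a rise beyond the scatter over compound 2 does not depend on the 3,4-dimethoxyphenyl group alone. Nothing measured on these compounds explains these differences, so the reason for them remains unknown.

Going by these compounds, compound 1 is reported as "not active" (no number reported) while compound 4 gives 21.4%, so any step involving compound 1 cannot be read, and what separates these two compounds remains open. Also open, on these data alone, is how an amine, a carboxylic acid or a longer chain on this phenyl ring would behave in this assay, and, with only one concentration tested, how these compounds compare in potency.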